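Amide aryl swap on a chalcone-type scaffold

A few compounds are considered here, and "the series" means these few. Any claim that something is new, unique, unknown or untested is made for them only; others in the source may bear on it.

Compound 2 `COc1cccc(OC)c1C(=O)Nc1ccc(C(=O)/C=C/c2nc(C)c(C)nc2C)cc1` gives 3380 nM in a functional assay on HepG2 cells (Homo sapiens) for antiproliferative activity, read by CCK-8 assay, with a stated time of 72 h (a lower number here means a stronger inhibitor, a higher number a weaker inhibitor), the higher of the two numbers recorded so far; its nearest neighbour is compound 1 `COc1ccc(C(=O)Nc2ccc(C(=O)/C=C/c3nc(C)c(C)nc3C)cc2)cc1OC`, which gives 2560 nM in this assay, and the step of a 1.3-fold higher number from compound 1 to compound 2 (0.12 log units; within the scatter) is within the scatter. Compound 3 `Cc1nc(C)c(/C=C/C(=O)c2ccc(NC(=O)c3ccc(F)cc3)cc2)nc1C` is not yet measured. It differs from compound 2 by 4-fluorophenyl in place of 2,6-dimethoxyphenyl on a carbonyl carbon. Among the compounds with values here, the only measured step that bears on this change is the aryl swap on the same carbonyl carbon from compound 1 to compound 2, which moved the number by little more than the scatter allows. On that basis, a further swap of the aryl group on the amide carbonyl is expected to leave the number roughly where it stands, with no shift beyond the scatter in either direction. For compound 3 the estimate in this assay is therefore 3000 nM, with a range from 1200 nM to 7500 nM, an expected step of a 1.1-fold lower number from compound 2 to compound 3 (0.05 log units; within the scatter).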

Compound 3, half-maximal inhibitory concentration: 2250 nM
Compound 3: middle estimate off by 1.3-fold (0.12 log units), on the high side, within the range that was stated.
By their numbers in this assay, from the lowest: compounds 3, 1 and 2 (each within the scatter of the next).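

In this assay, putting 4-fluorophenyl on the amide carbonyl gives a 1.5-fold lower number from compound 2 to compound 3 (0.18 log units; within the scatter) and a 1.1-fold lower number from compound 1 to compound 3 (0.06 log units; within the scatter), so compound 3 cannot be told apart from either dimethoxy compound. Compound 1 and compound 2 differed only in where their two methoxy groups sat, whereas compound 3 has neither methoxy group and a 4-fluorophenyl with no hydrogen-bond acceptors. The three aryl groups shown at this position therefore give numbers that lie within the scatter of one another, and nothing shown explains this result.

As far as these compounds go, it remains open whether an aryl group carrying an amine or a carboxylic acid, or a longer alkyl chain in place of the aryl ring, would give a number beyond the scatter. From the compounds shown here alone, the effect of changes elsewhere on the shared core also remains open.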